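A Pyridin-3-yl Replacement for 5-Chlorothiophen-2-yl

This account rests on a few compounds, and the source may have more. Where it says the series, first, only, none or still open, it means among the compounds named here.

Measured so far:
compound 1, `CCN(CC)C(=O)[C@@]1(c2ccc(Cl)s2)C[C@H]1CN`: > 10000 nM
compound 2, `CCN(CC)C(=O)[C@@]1(c2cc3cc(F)ccc3s2)C[C@H]1CN`: > 10000 nM

Compound 1 `CCN(CC)C(=O)[C@@]1(c2ccc(Cl)s2)C[C@H]1CN` and compound 2 `CCN(CC)C(=O)[C@@]1(c2cc3cc(F)ccc3s2)C[C@H]1CN` share a core and have been tested in an assay on HEK293 cells for inhibition of sodium-dependent dopamine transporter (Homo sapiens); on this read-out higher numbers stand for weaker inhibition and lower numbers for stronger inhibition. In this assay compound 1 gives > 10000 nM, which is a limit of the assay and not a number. In this assay compound 2 gives > 10000 nM, likewise a limit. Among the measured compounds shown here, compound 1 therefore stands where every value shown stands, at the limit of > 10000 nM in this assay, at which 2 of the 2 values shown sit; no number separates it from compound 2, and no step between measured compounds can be drawn.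

Compound 3 `CCN(CC)C(=O)[C@@]1(c2cccnc2)C[C@H]1CN` differs from compound 1 in one place: pyridin-3-yl in place of 5-chlorothiophen-2-yl on a saturated ring carbon. The shared core and the aminomethyl group are kept. Because both measured values sit at the limit of > 10000 nM in this assay, at which 2 of the 2 values shown sit, nothing measured gives a scale for this change. The expected step that the limit leaves unreadable from compound 1 to compound 3 is none beyond the scatter, with compound 3 expected to stay at the limit. For compound 3 the estimate is 15000 nM, with a range from 4000 nM to 60000 nM, and it is expected that the assay again reports only a limit.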

Compound 3, half-maximal inhibitory concentration: > 10000 nM
Compound 3 gave a limit, no number; the forecaster's own chance of this, stated with the estimate: 80%; the middle value is on the limit's open side.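

In this assay compound 3 gives > 10000 nM, which is a limit of the assay and not a number. No step from compound 1 to compound 3 can be read, because the values shown all stand at one limit: the limit of > 10000 nM in this assay, at which 3 of the 3 values shown sit.

The compounds shown leave open how far each lies from that limit, and whether any group in this place would give a measurable value in this assay.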